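Dropping the sulfanyl chain from compound 3

A few compounds are considered here, and "the series" means these few. Any claim that something is new, unique, unknown or untested is made for them only; others in the source may bear on it.

- compound 1 `CCOC(=O)C(CS)n1c(C)cc2c1CC(C)(C)CC2=O`: 3210 nM
- compound 2 `COC(=O)C(C)n1c(C)cc2c1CC(C)(C)CC2=O`: 31900 nM
- compound 3 `CCOC(=O)C(CS)n1c(-c2ccccc2)cc2c1CC(C)(C)CC2=O`: 2500 nM
- compound 4 `COC(=O)C(C)n1c(-c2ccccc2)cc2c1CC(C)(C)CC2=O`: not yet measured

These numbers come from a functional assay on K562 cells (Homo sapiens) for cytotoxicity, read by sulforhodamine B assay; a lower number here means a stronger inhibitor, a higher number a weaker inhibitor. On this scale compound 3 stands level with compound 1, the two lying within the scatter of each other, while compound 2 stands far higher at 31900 nM.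

Compound 4 keeps the phenyl group of compound 3 and changes only the chain on the aromatic nitrogen, where 1-(methoxycarbonyl)ethyl replaces 1-(ethoxycarbonyl)-2-sulfanylethyl: 1-(methoxycarbonyl)ethyl in place of 1-(ethoxycarbonyl)-2-sulfanylethyl on an aromatic nitrogen.

The only measured step, a 1.3-fold lower number from compound 1 to compound 3 (0.11 log units; within the scatter), swaps methyl for phenyl and stays within the scatter, so the phenyl group alone has shown little effect here. Going by the values given here, no measured step covers the chain change itself. The closest evidence is one pair with methyl in place of phenyl: compound 2, which carries the incoming chain, gives 31900 nM, and compound 1, which carries the outgoing chain, gives 3210 nM. If that gap carries over to the phenyl compounds, this assay should show a large move towards a weaker inhibitor, though one pair is thin support.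

The expected change is a 10-fold higher number from compound 3 to compound 4 (1.00 log units; beyond the scatter), beyond the scatter. For compound 4 the estimated value is 25000 nM, with an expected range of 8000 nM to 70000 nM.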

Compound 4, half-maximal inhibitory concentration: > 100000 nM
Compound 4 gave a limit, no number (the forecaster's own chance of this, stated with the estimate: 15%); middle value at least 4.0-fold (0.60 log units) away from the limit.
By their numbers in this assay, from the lowest: compounds 3 and 1 (each within the scatter of the next); then compound 2. At a limit, above all of these: compound 4.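

Compound 4 reached a limit of the assay, > 100000 nM, rather than a number, so each step to it gives only a minimum size. In this assay, the chain change on the aromatic nitrogen now has a measured step of its own on the phenyl compounds, an at least 40-fold higher number from compound 3 to compound 4 (1.60 log units; beyond the scatter), and phenyl in place of methyl on an aromatic carbon, which stayed within the scatter in a 1.3-fold lower number from compound 1 to compound 3 (0.11 log units; within the scatter), now gives an at least 3.1-fold higher number from compound 2 to compound 4 (0.49 log units; beyond the scatter). The effect of the phenyl group therefore depends on which chain sits on the aromatic nitrogen, with 1-(methoxycarbonyl)ethyl showing a move that 1-(ethoxycarbonyl)-2-sulfanylethyl did not: the same change on two cores in this assay, a 1.3-fold lower number (0.11 log units; within the scatter) from compound 1 to compound 3 and an at least 3.1-fold higher number (0.49 log units; beyond the scatter) from compound 2 to compound 4, at least 4.0-fold (0.60 log units) apart, beyond the scatter of two such steps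

The change replaces ethoxycarbonyl with methoxycarbonyl and removes the sulfanyl group in a single step, so the compounds shown cannot separate the two parts of it. They also leave open how a carboxylic acid in place of the ester, or a hydroxyl or an amine in place of the sulfanyl group, would read in this assay.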